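This account rests on a few compounds, and the source may have more. Where it says the series, first, only, none or still open, it means among the compounds named here.

Compound 1 `C=C1C(=O)[C@]23C[C@@]1(O)CC[C@H]2[C@@]12C=CC(=O)[C@](C)(C(=O)O1)[C@H]2[C@@H]3C(=O)OC`: 37200 nM
Compound 2 `C=C1C(=O)[C@]23C[C@@]1(O)CC[C@H]2[C@@]12C=CC(=O)[C@](C)(C(=O)O1)[C@H]2[C@@H]3C(=O)OCc1ccccc1`: 20500 nM

For the measured compounds named here, in a functional assay on HepG2 cells (Homo sapiens) for cytotoxicity, read by MTT assay (on this read-out higher numbers stand for weaker inhibition and lower numbers for stronger inhibition), compound 1 stands level with compound 2, the only other compound measured. Compound 3 `C=C1C(=O)[C@]23C[C@@]1(OC)CC[C@H]2[C@@]12C=CC(=O)[C@](C)(C(=O)O1)[C@H]2[C@@H]3C(=O)OC` differs from compound 1 by methyl in place of hydrogen on an oxygen on a saturated carbon, or hydroxy to methoxy. Going by the values given here, no measured step tests this change. The only one available, a 1.8-fold lower number from compound 1 to compound 2 (0.26 log units; within the scatter), lies elsewhere in the molecule and stays within the scatter, so it is a weak guide, and no step beyond the scatter is expected in this assay. The estimated step is a 1.1-fold lower number from compound 1 to compound 3 (0.05 log units; within the scatter). For compound 3 the expected value is 33000 nM, with an estimated range of 14000 nM to 75000 nM.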

Compound 3, half-maximal inhibitory concentration: 43500 nM
The estimate for compound 3 lay 1.3-fold (0.12 log units) below the measured number; the range from low to high includes it.
By their numbers in this assay, from the lowest: compounds 2, 1 and 3 (each within the scatter of the next, the first and the last beyond it).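

In this assay, methyl in place of hydrogen on an oxygen on a saturated carbon, or hydroxy to methoxy, gives a 1.2-fold higher number from compound 1 to compound 3 (0.07 log units; within the scatter), so the two compounds cannot be told apart. For the compounds shown here, this is the first reading at this position, and it shows that the hydrogen on this oxygen can be replaced by methyl without a measurable difference. Nothing available explains this result. From the compounds shown here alone, whether a longer chain or an amine-bearing chain on this oxygen would move the number beyond the scatter remains open.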